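A few compounds are considered here, and "the series" means these few. Any claim that something is new, unique, unknown or untested is made for them only; others in the source may bear on it.

Compound 2 `C=CCNc1nnc(SCC(=O)N(Cc2cccc([N+](=O)[O-])c2)c2ccc(F)cc2)s1` gives 56.5% in an assay on isolated protein for inhibition of Amine oxidase [flavin-containing] A (Homo sapiens), read by fluorescence and Amplex Red, with a stated time of 30 min, tested at 1 uM (on this read-out lower numbers stand for a weaker effect and higher numbers for a stronger effect at the one concentration tested), standing alongside compound 1 `CCCCNc1nnc(SCC(=O)N(Cc2cccc([N+](=O)[O-])c2)c2ccc(F)cc2)s1`, which gives 47.3%; the step of a number 9.2 percentage points higher from compound 1 to compound 2 (within the scatter), vinyl in place of propyl on a saturated chain carbon bound to a nitrogen on an aromatic ring, stays within the scatter. Compound 3 `CC(C)Nc1nnc(SCC(=O)N(Cc2cccc([N+](=O)[O-])c2)c2ccc(F)cc2)s1` differs from compound 2 by isopropyl in place of allyl on a nitrogen on an aromatic ring. Within the data shown here, only that one step bears on it, and it was small, so a step of a number 6.5 percentage points lower from compound 2 to compound 3 (within the scatter) not beyond the scatter is expected. Compound 3 is therefore estimated at 50%, in this assay expected between 35% and 65%.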

Compound 3, a percentage reported as inhibition, at one concentration (the size of the read-out at that concentration, not a potency): 46%
Estimate against measurement, compound 3: 4 percentage points above, and the stated range covers the measured number.
By their numbers in this assay, from the lowest: compounds 3, 1 and 2 (each within the scatter of the next, the first and the last beyond it).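

In this assay, among these compounds, putting isopropyl in place of allyl on the nitrogen gives a number 10.5 percentage points lower from compound 2 to compound 3 (beyond the scatter), the first step at this position to pass beyond the scatter, though only modestly. Isopropyl in place of butyl gives a number 1.3 percentage points lower from compound 1 to compound 3 (within the scatter), so these two groups cannot be told apart here, and allyl separates only from isopropyl. Nothing available explains this difference. The compounds shown leave open how a cyclopropyl group, a propargyl group or a longer chain on this nitrogen would compare. They also leave open whether a free amine would retain the effect.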